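The compounds below may be only part of what the source reports. "The series", "measured", "known", "first", "only" and "open" are said of these compounds alone.

The study compares cytotoxicity read in a functional assay on UACC-257 cells (Homo sapiens) for cytotoxicity, read by sulforhodamine B assay, with a stated time of 48 h; on this read-out lower numbers stand for stronger inhibition of growth and higher numbers for weaker inhibition of growth. Compound 1, `Nc1nc(Cl)c2ncn(Cc3ccccc3CCl)c2n1`, gives 13200 nM in this assay, the higher of the two numbers measured. Compound 2, `ClCc1cccc(Cn2cnc3nc(Cl)nc(Cl)c32)c1`, gives 3460 nM in this assay, a lower number that lies beyond the scatter. Compound 3, `ClCc1ccccc1Cn1cnc2c(Cl)ncnc21`, has not yet been measured. It differs from compound 1 as follows: hydrogen in place of amino on an aromatic carbon. For the measured compounds named here, with no measured pair showing this change, the step is expected to be small in either direction, and the estimated step from compound 1 to compound 3 is a 1.3-fold lower number from compound 1 to compound 3 (0.12 log units; within the scatter). Compound 3 is therefore expected to give about 10000 nM in this assay, within a range from 3000 nM to 35000 nM.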

Compound 3, concentration for 50% growth inhibition: 10700 nM
The estimate for compound 3 lay 1.1-fold (0.03 log units) below the measured number; the range from low to high includes it.
By their numbers in this assay, from the lowest: compound 2; then compounds 3 and 1 (each within the scatter of the next).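

In this assay, hydrogen in place of amino on the aromatic carbon between two ring nitrogen atoms gives a 1.2-fold lower number from compound 1 to compound 3 (0.09 log units; within the scatter), so the amino group at this position makes no difference that can be read on this read-out. For the compounds shown here, this is the first measured pair to isolate a change at this carbon. Nothing measured here offers an explanation for this result.

On these data alone, it remains open whether a methoxy or a dimethylamino group on this carbon would move the number beyond the scatter. As far as these compounds go, it is also open whether amino and hydrogen would remain this close if the rest of the compound were changed.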